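A few compounds are considered here, and "the series" means these few. Any claim that something is new, unique, unknown or untested is made for them only; others in the source may bear on it.

Measured so far:
Compound 1, `COc1cc(OC)c(OC)cc1/C=C/COC(=O)/C=C/c1ccc(Br)cc1`, gives 100% in a functional assay on the whole organism (strain Kunming) with Mus musculus as the target, with a stated time of 0.5 h, at a dose of 100 mg/kg by the intraperitoneal route; a lower number here means a stronger effect, a higher number a weaker effect of the compound at the dose given.
Compound 2, `COc1cc(OC)c(OC)cc1/C=C/COC(=O)/C=C/c1ccccc1Cl`, gives 100% in this assay.

Among the measured compounds shown here, on these numbers compound 2 stands level with compound 1: the only measured step, no change at the digits printed from compound 1 to compound 2 (within the scatter), exchanged one halogen-bearing phenyl ring for another and left the read-out where it was, within the scatter.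

The next compound, compound 3, `COc1cccc(/C=C/C(=O)OC/C=C/c2cc(OC)c(OC)cc2OC)c1`, has not yet been measured in this assay. It differs from compound 2 in a single place: 3-methoxyphenyl in place of 2-chlorophenyl on a double-bonded chain carbon bound to a double-bonded chain carbon.

For the measured compounds named here, only the step from compound 1 to compound 2 bears on this change, and it was flat. It swapped two halogen-bearing rings, whereas here a methoxy-bearing ring enters, so the guidance is indirect and the data give no direct reading on a methoxyphenyl at this position. With two identical values and one flat step, the expected step of a number 5 percentage points lower from compound 2 to compound 3 (within the scatter) is none beyond the scatter, with some room downward since the values sit at the top of the scale. Compound 3 is estimated to give 95% in this assay, with a likely range from 75% to 100%.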

Compound 3, a percentage reported as activity, at one dose (the size of the read-out at that dose, not a potency): 100%
Estimate against measurement, compound 3: 5 percentage points below; low and high end bracket the measured number.
By their numbers in this assay, from the lowest: compounds 1, 2 and 3 (each within the scatter of the next).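

Until now only halogen-bearing rings had been seen at this place, on a double-bonded chain carbon bound to a double-bonded chain carbon, so the flat first step could have been a feature of halogens alone. In this assay, 3-methoxyphenyl, which brings an oxygen and a hydrogen-bond acceptor that neither halogen-bearing ring has under the same count, reads the same as 2-chlorophenyl (no change at the digits printed from compound 2 to compound 3 (within the scatter)) and the same as 4-bromophenyl (no change at the digits printed from compound 1 to compound 3 (within the scatter)), so the flat reading now spans a ring with a halogen and a ring with a methoxy group, and with the substituent sitting at three different printed ring positions. Nothing measured on these groups is at hand to explain that sameness.

With all three compounds on one reading, the set offers no spread by which to rank the rings, and it does not show whether any group at this place can bring the number down. An amine or a carboxylic acid on the ring, or a longer chain in its place, remains an open test of that, as does any alteration of the shared core.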